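A few compounds are considered here, and "the series" means these few. Any claim that something is new, unique, unknown or untested is made for them only; others in the source may bear on it.

Compound 2, `CC1(C)C[C@H](CN([C@H](CCC(F)(F)F)C(N)=O)S(=O)(=O)c2ccc(Cl)cc2)O1`, gives 18.1 10^-6 cm/s in an ADME assay on MDCKII-LE cells (Canis lupus familiaris) for permeability, read by transwell migration, in the apical to basolateral direction; on this read-out lower numbers stand for lower permeability and higher numbers for higher permeability. Among the three compounds measured there it carries the lowest number, though its nearest neighbour compound 3, `CC1(C)CO[C@@H]1CN([C@H](CCC(F)(F)F)C(N)=O)S(=O)(=O)c1ccc(Cl)cc1`, with 22.3 10^-6 cm/s, and its furthest neighbour compound 1, `NC(=O)[C@@H](CCC(F)(F)F)N(CC1COC1)S(=O)(=O)c1ccc(Cl)cc1`, with 25.4 10^-6 cm/s, both lie within the scatter of it, so no order can be read among the three.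

Compound 4, `NC(=O)[C@@H](CCC(F)(F)F)N(C[C@@H]1CCCCO1)S(=O)(=O)c1ccc(Cl)cc1`, differs from compound 2 in one place: oxan-2-yl in place of 4,4-dimethyloxetan-2-yl on a saturated chain carbon bound to a sulfonamide nitrogen. The steps measured so far all swap one small saturated ring for another at this same position. They read a 1.4-fold lower number from compound 1 to compound 2 (0.15 log units; within the scatter), a 1.1-fold lower number from compound 1 to compound 3 (0.06 log units; within the scatter) and a 1.2-fold higher number from compound 2 to compound 3 (0.09 log units; within the scatter); none of them leaves the scatter. Going by the values given here, no measured step carries a six-membered ring into this place, so the change from compound 2 to compound 4 is not covered directly, and the only guide is that three rearrangements of the same atoms at this position have left this assay unmoved.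

The expectation for compound 4 is therefore a step of a 1.1-fold higher number from compound 2 to compound 4 (0.04 log units; within the scatter), which is no movement beyond the scatter. The estimate for compound 4 in this assay is 20 10^-6 cm/s, with a range from 12 10^-6 cm/s to 33 10^-6 cm/s.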

Compound 4, apparent permeability: 15.4 10^-6 cm/s
Compound 4: the middle estimate sits 1.3-fold (0.11 log units) above what was measured; low and high end bracket the measured number.
By their numbers in this assay, from the lowest: compounds 4, 2, 3 and 1 (each within the scatter of the next).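

Carrying a six-membered ring into this place, on a saturated chain carbon bound to a sulfonamide nitrogen, leaves this assay within the scatter against each of the three four-membered rings (a 1.2-fold lower number from compound 2 to compound 4 (0.07 log units; within the scatter); a 1.4-fold lower number from compound 3 to compound 4 (0.16 log units; within the scatter); a 1.6-fold lower number from compound 1 to compound 4 (0.22 log units; within the scatter)). The flat picture at this position therefore no longer rests on oxetane isomers alone: going from a (4,4-dimethyloxetan-2-yl)methyl group to an (oxan-2-yl)methyl group, with the same heavy atoms joined differently, produces no readable change, and compounds 1 to 4 cannot be ordered on this read-out. No other measurement bears on this result, so the data describe the absence of a change without accounting for it.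

As far as these compounds go, all four compounds keep a saturated ring with an ether oxygen at this place, so it remains open whether a cyclohexyl ring, a piperidine amine, a carboxylic acid or a longer open chain would stay within the scatter. Also open, from the compounds shown here alone, is whether the oxan-2-yl group with the opposite configuration at its stereocentre would read the same as compound 4.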